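A few compounds are considered here, and "the series" means these few. Any claim that something is new, unique, unknown or untested is made for them only; others in the source may bear on it.

Compound 1 (`Cc1ccc(-c2ccccc2NCC2=NCCN2)n1C`) and compound 2 (`CCCCn1ncnc1-c1ccccc1NCC1=NCCN1`) share a core but carry different five-membered rings on it. In an in vitro functional assay on cells (Fibroblast) for agonist activity at Alpha-1B adrenergic receptor (Homo sapiens) (a higher number here means that more compound is needed for the effect, a lower number that less compound is needed), compound 2 gives 200 nM. For compound 1 the same this assay reports only a limit, < 100000 nM, rather than a number, and it is the one of the two measured values that sits at the limit of < 100000 nM in this assay, at which 1 of the 2 values shown sits. Where compound 1 truly stands therefore remains open. Compound 3 (`Cn1cccc1-c1ccccc1NCC1=NCCN1`) has not yet been measured; it differs from compound 1 by hydrogen in place of methyl on an aromatic carbon. No measured pair shows the effect of such a change, and with only a limit for compound 1 the size and direction of the step cannot be read from the numbers shown; a change beyond the usual scatter in either direction would not surprise. Compound 3 is expected to give about 3000 nM, in the range 300 nM to 30000 nM. Going by the values given here, the step expected from a step that the limit leaves unreadable from compound 1 to compound 3 is thus only a rough guess, resting on the single number from compound 2.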

Compound 3, half-maximal effective concentration: < 100000 nM
Compound 3: a limit, no number (the forecaster's own chance of this, stated with the estimate: 20%); the middle value is on the limit's open side.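

In this assay compound 3 gives < 100000 nM as a limit and not a number. Compound 1 also has only a limit, so no step between compound 1 and compound 3 can be read: the limit of < 100000 nM in this assay, at which 2 of the 3 values shown sit.
Still open, going by these compounds, is where compound 1 and compound 3 truly stand, and what hydrogen in place of methyl does to the value.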